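A Fluoro Step Repeated on a Second Core

This account rests on a few compounds, and the source may have more. Where it says the series, first, only, none or still open, it means among the compounds named here.

Two closely related cores are compared here. Compound 1 `COc1cc2c(Oc3ccc(NC(=O)c4cn(-c5ccccc5)nn4)cc3F)ccnc2cc1OCCCN1CCCCC1` and compound 3 `COc1cc2c(Oc3ccc(NC(=O)c4cn(-c5ccccc5)nn4)cc3F)ccnc2cc1OCCCN1CCN(C)CC1` differ only at the end of the chain: 4-methylpiperazin-1-yl in place of piperidin-1-yl on a saturated chain carbon, three bonds along the chain from an oxygen on an aromatic ring. In a functional assay on A549 cells (Homo sapiens) for cytotoxicity, read by MTT assay, with a stated time of 72 h (a lower number here means a stronger inhibitor, a higher number a weaker inhibitor), compound 1 gives 130 nM and compound 3 gives 160 nM; the measured difference is a 1.2-fold higher number from compound 1 to compound 3 (0.09 log units; within the scatter). On the first core, the change fluoro in place of hydrogen on an aromatic carbon leads to compound 2 `COc1cc2c(Oc3ccc(NC(=O)c4cn(-c5ccccc5F)nn4)cc3F)ccnc2cc1OCCCN1CCCCC1`, which gives 2770 nM, a step of a 21-fold higher number from compound 1 to compound 2 (1.33 log units; beyond the scatter). Compound 4 `COc1cc2c(Oc3ccc(NC(=O)c4cn(-c5ccccc5F)nn4)cc3F)ccnc2cc1OCCCN1CCN(C)CC1` carries the same change on the second core, (fluoro in place of hydrogen on an aromatic carbon), in identical surroundings. Because a 21-fold higher number from compound 1 to compound 2 (1.33 log units; beyond the scatter) is large and the two cores gave closely matching numbers, the change is expected to carry over, giving an estimated 19-fold higher number from compound 3 to compound 4 (1.27 log units; beyond the scatter). Compound 4 is therefore estimated at 3000 nM, with a likely range from 1000 nM to 9000 nM.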

Compound 4, half-maximal inhibitory concentration: 250 nM
Estimate against measurement, compound 4: 12-fold (1.08 log units) above, and the stated range ends above it.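

In this assay, the fluoro change gives a 1.6-fold higher number from compound 3 to compound 4 (0.19 log units; within the scatter), so on this core it stays within the scatter, and the two cores disagree about the same change: the same change on two cores in this assay, a 21-fold higher number (1.33 log units; beyond the scatter) from compound 1 to compound 2 and a 1.6-fold higher number (0.19 log units; within the scatter) from compound 3 to compound 4, 14-fold (1.13 log units) apart, beyond the scatter of two such steps

Read the other way, 4-methylpiperazin-1-yl in place of piperidin-1-yl gives an 11-fold lower number from compound 2 to compound 4 (1.04 log units; beyond the scatter) when 2-fluorophenyl is present, yet stays within the scatter with plain phenyl: the same change on two cores in this assay, a 1.2-fold higher number (0.09 log units; within the scatter) from compound 1 to compound 3 and an 11-fold lower number (1.04 log units; beyond the scatter) from compound 2 to compound 4, 14-fold (1.13 log units) apart, beyond the scatter of two such steps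

So in these four compounds the size of each change depends on the other, and a step measured on one core is no safe guide to the next; the numbers do not show why.

From the compounds shown here alone, it remains open whether chloro or methoxy in place of the fluoro would follow compound 2 or compound 4. Going by these compounds, it is also open how a morpholine at the end of the chain would behave alongside 2-fluorophenyl.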